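The compounds below may be only part of what the source reports. "The series", "measured", "known", "first", "only" and "open" are said of these compounds alone.

Working notes on the series, read in a functional assay on HEK293 cells (Homo sapiens) for cytotoxicity; on this read-out higher numbers stand for lower toxicity in this test and lower numbers for higher toxicity in this test. Compound 1 `COc1ccc([C@H]2CC(=O)N(c3cccc(N(C)C)c3)C2)cc1OC1CCCC1`, with dimethylamino on an aromatic carbon, gives > 10000 nM, which is a limit of the assay and not a number. Compound 2 `COc1ccc([C@H]2CC(=O)N(c3cccc(C#N)c3)C2)cc1OC1CCCC1`, with cyano at that carbon, gives > 10000 nM, again a limit. Compound 3 `COc1ccc([C@H]2CC(=O)N(c3cccc([S+](C)[O-])c3)C2)cc1OC1CCCC1` gives > 10000 nM, and this too is only a limit. The whole set therefore stands at one ceiling: the limit of > 10000 nM in this assay, at which 3 of the 3 values shown sit.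

The next change leads to compound 4 `COc1ccc([C@H]2CC(=O)N(c3cccc(NCC4CCOC4)c3)C2)cc1OC1CCCC1`: a group of 7 heavy atoms (5 carbon, 1 nitrogen, 1 oxygen; one five-membered non-aromatic ring with 1 hetero atom) in place of a group of 3 heavy atoms (1 carbon, 1 oxygen, 1 sulfur; no ring), on an aromatic carbon. In words, a group of 7 heavy atoms with one five-membered non-aromatic ring replaces a group of 3 heavy atoms with no ring, on an aromatic carbon, meta to a large group.

Within the data shown here, three measured steps bear on this exchange: a step that the two limits leave unreadable from compound 1 to compound 2, a step that the two limits leave unreadable from compound 1 to compound 3 and a step that the two limits leave unreadable from compound 2 to compound 3. None of them has a readable size. None involves a group with a ring, so the entering group lies outside what has been measured. No clear direction can be expected, and the most likely outcome is another report at the limit, because the limit of > 10000 nM in this assay, at which 3 of the 3 values shown sit, is all the series offers. The estimated change is a step that the limit leaves unreadable from compound 3 to compound 4. For compound 4 the expected value is 15000 nM, with an estimated range of 5000 nM to 30000 nM.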

Compound 4, half-maximal cytotoxic concentration: > 10000 nM
Compound 4 was reported as a limit; the forecaster's own chance of this, stated with the estimate: 85%; the middle value does not contradict the limit.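

Compound 4 gives > 10000 nM, which is a limit of the assay and not a number, so the steps to compound 4 from compound 1, compound 2 and compound 3 cannot be read. The series stays at one ceiling: the limit of > 10000 nM in this assay, at which 4 of the 4 values shown sit. The compounds shown leave open whether this assay gives a measurable value for any group on this aromatic carbon.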